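The compounds below may be only part of what the source reports. "The series", "measured", "known", "first", "only" and "open" are said of these compounds alone.

Compound 1 `N#CC1=C(N)Oc2c(c3nc4ccccc4nc3c3ccccc23)C12C(=O)N(Cc1cnnn1-c1ccccc1Cl)c1ccccc12` — a functional assay on MCF7 cells (Homo sapiens) for antiproliferative activity, read by MTT assay, with a stated time of 48 h; on this read-out lower numbers stand for stronger inhibition and higher numbers for weaker inhibition: > 50000 nM, a limit of the assay and not a number.
Compound 2 `COc1ccc(-n2nncc2CN2C(=O)C3(C(C#N)=C(N)Oc4c3c3nc5ccccc5nc3c3ccccc43)c3ccccc32)cc1` — in this assay compound 2 gives > 50000 nM, again a limit of the assay.

On the numbers shown, compound 2 stands at the assay limit with no resolved value. For the measured compounds named here, the single step between measured compounds, a step that the two limits leave unreadable from compound 1 to compound 2, cannot be sized because of the limit of > 50000 nM in this assay, at which 2 of the 2 values shown sit. Compound 3 `Cc1ccc(C)c(-n2nncc2CN2C(=O)C3(C(C#N)=C(N)Oc4c3c3nc5ccccc5nc3c3ccccc43)c3ccccc32)c1` is the next member; it differs from compound 2 by 2,5-dimethylphenyl in place of 4-methoxyphenyl on an aromatic nitrogen. Going by the values given here, no measured step bears on this change with a readable size, as the one step recorded across the series is unreadable. No step beyond the scatter is expected in this assay in either direction, and a further limit is the most likely outcome. Compound 3 is therefore estimated at 60000 nM, within the range 20000 nM to 300000 nM. The expected step is a step that the limit leaves unreadable from compound 2 to compound 3.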

Compound 3, half-maximal inhibitory concentration: > 50000 nM
Compound 3 gave a limit, no number; the forecaster's own chance of this, stated with the estimate: 85%; the middle value lies beyond the limit too.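

Compound 3 joins compound 1 and compound 2 at a limit and not a number, so no step among the three can be read: the limit of > 50000 nM in this assay, at which 3 of the 3 values shown sit.

Still open, from the compounds shown here alone, is whether any group on that aromatic nitrogen gives a resolved value in this assay, and how 2-chlorophenyl, 4-methoxyphenyl and 2,5-dimethylphenyl compare.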